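Side-chain swap on the shared core: compound 2 to compound 3

The compounds below may be only part of what the source reports. "The series", "measured", "known", "first", "only" and "open" are said of these compounds alone.

Compound 2 `O=C1c2c[n+]([O-])c3ccccc3c2C(=O)c2c1c1ccccc1n2CCCCN1CCNCC1` gives 12000 nM in a functional assay on MCF7 cells (Homo sapiens) for cytotoxicity, read by MTT assay, with a stated time of 72 h (a higher number here means a weaker inhibitor, a lower number a stronger inhibitor), the highest of the two numbers recorded. For the measured compounds named here, compound 1 `CC1(C)OCC(Cn2cc(Cn3c4c(c5ccccc53)C(=O)c3c[n+]([O-])c5ccccc5c3C4=O)nn2)O1` gives 290 nM in this assay, a lower number by a margin beyond the scatter, though no single-place step connects the two. Compound 3 `O=C1c2c[n+]([O-])c3ccccc3c2C(=O)c2c1c1ccccc1n2CCCN1CCC(O)CC1` differs from compound 2 as 4-hydroxypiperidin-1-yl in place of (piperazin-1-yl)methyl on a saturated chain carbon, three bonds along the chain from an aromatic nitrogen. Going by the values given here, no measured step of this kind exists in the set, so the size of the change is open. A modest movement toward a lower number, near the scatter, is expected a 1.5-fold lower number from compound 2 to compound 3 (0.18 log units; within the scatter). Compound 3 is estimated at 8000 nM, with a range from 2500 nM to 25000 nM.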

Compound 3, half-maximal inhibitory concentration: 190 nM
The estimate for compound 3 lay 42-fold (1.62 log units) above the measured number; the whole stated range lies above it.
By their numbers in this assay, from the lowest: compounds 3 and 1 (each within the scatter of the next); then compound 2.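

In this assay, for the compounds shown here, the side chain on the aromatic nitrogen gives the first readable single-place change: replacing 4-(piperazin-1-yl)butyl with 3-(4-hydroxypiperidin-1-yl)propyl on the shared core gives a 63-fold lower number from compound 2 to compound 3 (1.80 log units; beyond the scatter) as a large step. This position therefore tolerates substantial movement in the read-out with the core unchanged. No available measurement accounts for the step.

The step alters both ring and chain length, and their separate contributions remain unresolved. A 4-(4-hydroxypiperidin-1-yl)butyl or 3-(piperazin-1-yl)propyl chain would separate them.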